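Benzyl ester of compound 2 in the tail flick test

This account rests on a few compounds, and the source may have more. Where it says the series, first, only, none or still open, it means among the compounds named here.

Measured compounds and their values:
- Compound 1, `O=C(CN(c1nc(Cl)nc2[nH]cnc12)C1CC1)NCC(=O)OCc1ccccc1`: 21.7%
- Compound 2, `N=C(N)NCCC[C@H](NC(=O)CN(c1nc(Cl)nc2[nH]cnc12)C1CC1)C(=O)O`: 17%
- Compound 3, `CC[C@H](C)[C@H](NC(=O)CN(c1nc(Cl)nc2[nH]cnc12)C1CC1)C(=O)O`: 21.4%

All three compounds share one core and were tested in a functional assay on the whole organism (Tail, strain ICR) with Mus musculus as the target, in the tail flick test, with a stated time of 120 min, at a dose of 25 umol/kg by the oral route; on this read-out lower numbers stand for a weaker effect and higher numbers for a stronger effect at the one dose given. Compound 2 gives the smallest of the three numbers, but its distance to compound 3 and to compound 1 is in each case within the scatter, so the three results cannot be told apart.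

The unmeasured compound 4, `N=C(N)NCCC[C@H](NC(=O)CN(c1nc(Cl)nc2[nH]cnc12)C1CC1)C(=O)OCc1ccccc1`, differs from compound 2 by benzyl in place of hydrogen on an oxygen next to a carbonyl group. Among the measured pairs, only one step of a single change exists, a number 4.4 percentage points higher from compound 2 to compound 3 (within the scatter), and it changes a different group at a different place, so it says nothing direct about a benzyl in place of hydrogen on an oxygen next to a carbonyl group. Compound 1 already carries a benzyloxycarbonyl group and gives 21.7%, a number close to that of compound 2, but compound 1 and compound 2 differ in more than one place, so their two values show only that both lie in the same narrow band.

For the measured compounds named here, with no step of this kind to lean on, the expected change is none beyond the scatter: for compound 4 the step is estimated as a number 3 percentage points higher from compound 2 to compound 4 (within the scatter). Compound 4 is therefore expected to give about 20%, within a range from 8% to 33%.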

Compound 4, a percentage reported as activity, at one dose (the size of the read-out at that dose, not a potency): 10.2%
Estimate against measurement, compound 4: 9.8 percentage points above, and the stated range covers the measured number.
By their numbers in this assay, from the lowest: compounds 4, 2, 3 and 1 (each within the scatter of the next, the first and the last beyond it).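

In this assay, turning the carboxy group into benzyloxycarbonyl gives a number 6.8 percentage points lower from compound 2 to compound 4 (within the scatter) and so brings no change that can be told from the usual scatter of repeated measurements. The first difference that clears the scatter comes from the saturated chain carbon bound to an amide-type nitrogen and a carbonyl carbon: with the benzyl group present in both compounds, a group of 7 heavy atoms (4 carbon, 3 nitrogen; no ring) in place of a hydrogen atom gives a number 11.5 percentage points lower from compound 1 to compound 4 (beyond the scatter) as a modest step. No measured evidence is available to explain either step.

The compounds shown do not tell what a methyl or ethyl group on the same oxygen would give, or what an amide would give in place of the benzyloxycarbonyl group. They also leave open how a simple amine or a longer carbon chain on the saturated chain carbon would compare, and whether benzyl would give a similar step on compound 3.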